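Methoxy to phenoxy on the oxygen: expected maximal response

The source may hold more compounds than are shown below. What is called first, only, known or untested is meant among the compounds shown, and "the series" means these compounds.

Measured so far:
compound 1 `CCCn1ccc2cc(-c3cccnc3)cc(Cl)c2c1=O` — 83%
compound 2 `CCCn1ccc2cc(-c3ccc(N(C)C)nc3)cc(Cl)c2c1=O` — 85%
compound 3 `CCCn1ccc2cc(-c3ccc(OC)nc3)cc(Cl)c2c1=O` — 121%

In a functional assay on CHO cells for agonist activity at metabotropic glutamate receptor 2 (Homo sapiens), read by GTPgammaS binding (on this read-out higher numbers stand for larger maximal responses and lower numbers for smaller maximal responses), compound 3 gives 121%, the highest of the three values. Its lead over the others is beyond the scatter: a number 38 percentage points higher from compound 1 to compound 3 (beyond the scatter) and a number 36 percentage points higher from compound 2 to compound 3 (beyond the scatter). Between the other two the step is a number 2 percentage points higher from compound 1 to compound 2 (within the scatter), within the scatter.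

Compound 4 `CCCn1ccc2cc(-c3ccc(Oc4ccccc4)nc3)cc(Cl)c2c1=O` differs from compound 3 by phenyl in place of methyl on an oxygen on an aromatic ring. Going by the values given here, no measured step swaps a group on that oxygen; the three measured steps all concern the group on the aromatic carbon, so they bear only indirectly. As far as these compounds go, the oxygen that came with the large rise is kept in compound 4, so a large loss is not expected, yet a methyl-to-phenyl swap is untested here and some fall-back toward the values of compound 1 and compound 2 is allowed for.

Compound 4 is expected to give about 100%, within 70% to 130%. This corresponds to an expected step of a number 21 percentage points lower from compound 3 to compound 4 (beyond the scatter), which may well lie within the scatter.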

Compound 4, largest response reached (Emax), in percent of the reference or control that the assay uses: 92%
Compound 4: middle estimate off by 8 percentage points, on the high side, within the range that was stated.
By their numbers in this assay, from the lowest: compounds 1, 2 and 4 (each within the scatter of the next); then compound 3.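

In this assay, keeping the oxygen on the aromatic carbon is not enough to hold the high response of compound 3: phenyl in place of methyl on that oxygen gives a number 29 percentage points lower from compound 3 to compound 4 (beyond the scatter) and shows that the group on the oxygen matters at this position. Phenoxy in place of dimethylamino gives a number 7 percentage points higher from compound 2 to compound 4 (within the scatter) and phenoxy in place of hydrogen gives a number 9 percentage points higher from compound 1 to compound 4 (within the scatter) so that, among these four compounds, only methoxy stands clear of the others. No available data explain the loss on going from methyl to phenyl.

Open, as far as these compounds go, is whether ethoxy, a longer alkoxy chain or benzyloxy would stay near methoxy or fall to the level of phenoxy. Also open, from the compounds shown here alone, is whether a methylamino group or a substituted phenoxy would separate from the rest.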